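Adding a Diethylaminopropyl Arm to Compound 2

A few compounds are considered here, and "the series" means these few. Any claim that something is new, unique, unknown or untested is made for them only; others in the source may bear on it.

Among the compounds with values here, in an ADME assay on L6 cells (Rattus norvegicus) for cytotoxicity (a lower number here means a stronger inhibitor, a higher number a weaker inhibitor), compound 2 `CCNC(C)c1cc2c(cc1OC)OC(C)(C)C=C2` gives 176000 nM and this is the higher of the two numbers measured so far. Within the data shown here, the only comparison is compound 1 `COc1cc2c(cc1C(C)NC(=O)c1ccccc1)C=CC(C)(C)O2` at 34800 nM which carries benzoyl on the amine nitrogen where compound 2 carries ethyl. Among the measured compounds shown here, that swap is the one measured step of a 5.1-fold higher number from compound 1 to compound 2 (0.70 log units; beyond the scatter) and it is modest but beyond the scatter.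

Compound 3 `CCN(CC)CCCC(C)NC(C)c1cc2c(cc1OC)OC(C)(C)C=C2` keeps the shared core and differs from compound 2 by a single change 3-(diethylamino)propyl in place of hydrogen on a saturated chain carbon bound to an amine nitrogen and a saturated chain carbon in which 3-(diethylamino)propyl replaces hydrogen on a saturated chain carbon bound to an amine nitrogen and a saturated chain carbon. For the measured compounds named here, no measured step shows this group, so the guide is indirect. Compound 1 has the bulkier substituent on that nitrogen and the lower number, yet two compounds make a hint and not a pattern. A step of similar modest size towards a lower number therefore seems reasonable, and the expected step is a 4.4-fold lower number from compound 2 to compound 3 (0.64 log units; beyond the scatter) with real uncertainty. For compound 3 the estimated value is 40000 nM with an expected range of 12000 nM to 130000 nM in this assay.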

Compound 3, half-maximal inhibitory concentration: 41900 nM
For compound 3 the middle estimate is 1.0-fold (0.02 log units) below the measured one; the measured number falls inside the stated range.
By their numbers in this assay, from the lowest: compounds 1 and 3 (each within the scatter of the next); then compound 2.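

In this assay, putting 3-(diethylamino)propyl in place of hydrogen on a saturated chain carbon bound to an amine nitrogen and a saturated chain carbon gives a 4.2-fold lower number from compound 2 to compound 3 (0.62 log units; beyond the scatter). Within the data shown here, the earlier step involved a change on the amine nitrogen itself, so this is the first sign that a change at this chain carbon can also move the number by more than the usual scatter, and the entering group does so without containing a ring. No accompanying evidence is available to explain this step.

The compounds shown leave open whether the step comes from the propyl chain or from the diethylamino group at its end, a question that a plain butyl chain at the same place could help to separate. Also open, going by these compounds, is whether a longer chain, or a chain ending in a carboxylic acid, would give a lower or a higher number, since a single step at this position cannot show a trend.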